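The compounds below may be only part of what the source reports. "The series", "measured", "known", "first", "only" and "open" are said of these compounds alone.

For the measured compounds named here, in an in vitro ADME assay on microsomes from liver (Homo sapiens) for metabolic stability (a higher number here means faster removal of the compound, a lower number slower removal), compound 3 `FC(F)Oc1ccccc1C1Cc2nccn2C1` gives 22 mL.min-1.g-1, the only actual number in this small set. Compound 1 `COCc1ccccc1C1Cc2nccn2C1` gives < 7 mL.min-1.g-1, which is a limit of the assay and not a number. For compound 2 `NC(=O)c1ccccc1C1Cc2nccn2C1` the entry is "not determined" (no result reported), so it offers no guidance.

Compound 4 `N#Cc1ccccc1C1Cc2nccn2C1` differs from compound 3 by cyano in place of difluoromethoxy on an aromatic carbon. Going by the values given here, the only measured step that bears on this is an at least 3.1-fold higher number from compound 1 to compound 3 (0.49 log units; beyond the scatter), in which difluoromethoxy entered in place of methoxymethyl. That step is a single example, and its size is a lower bound. Removing the same difluoromethoxy group from compound 3 therefore points to a lower number, though cyano itself has not been measured here. The low end of the scale may come into play: the limit of < 7 mL.min-1.g-1 in this assay, at which 1 of the 3 values shown sits.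

The expected change is a 2.4-fold lower number from compound 3 to compound 4 (0.39 log units; beyond the scatter), a modest step down in this assay. For compound 4 the estimate is 9 mL.min-1.g-1, with an expected range of 5 mL.min-1.g-1 to 20 mL.min-1.g-1.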

Compound 4, intrinsic clearance in microsomes: < 7 mL.min-1.g-1
Compound 4: only a limit was reported (the forecaster's own chance of this, stated with the estimate: 45%); at least 1.2-fold (0.10 log units) between middle value and limit.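

Cyano in place of difluoromethoxy on an aromatic carbon gives an at least 3.1-fold lower number from compound 3 to compound 4 (0.49 log units; beyond the scatter) in this assay, the first measured step away from difluoromethoxy at this position. Compound 4 gives < 7 mL.min-1.g-1, which is a limit of the assay and not a number. Difluoromethoxy now stands above both methoxymethyl and cyano at this position, and two different groups reach the same low end of the scale: the limit of < 7 mL.min-1.g-1 in this assay, at which 2 of the 4 values shown sit.

Going by these compounds, the step from compound 1 to compound 4 cannot be read, which leaves the order of methoxymethyl and cyano open, and the full size of the step from compound 3 is also open. On these data alone, whether an amine, a carboxylic acid or a longer chain at this position would sit at the limit or return to a readable number remains open.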